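Removing a methyl from a phenolic oxygen in a cytotoxicity series

A few compounds are considered here, and "the series" means these few. Any claim that something is new, unique, unknown or untested is made for them only; others in the source may bear on it.

Compound 1 `COc1cc(C)cc(-c2nn(CC#N)cc2-c2ccnc(-c3ccc(N(C)C)cc3)c2)c1`: 96%
Compound 2 `COc1cc(C)cc(-c2nn(CC#N)cc2-c2ccc(-c3cccc(C(C)=O)c3)nc2)c1`: 88%

Of the compounds shown here, two have been measured in a functional assay on PC-3 cells (Homo sapiens) for cytotoxicity, read by sulforhodamine B assay, with a stated time of 48 h, tested at 0.01 uM; a lower number here means a stronger effect, a higher number a weaker effect of the compound at the concentration tested. Compound 1 gives 96%, the higher of the two numbers, while compound 2 gives 88%; the gap between them lies within the scatter, so neither can be called the stronger. Both share a core bearing a nitrile-containing side chain and differ only in their outer aromatic parts.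

Compound 3 `Cc1cc(O)cc(-c2nn(CC#N)cc2-c2ccnc(-c3ccc(N(C)C)cc3)c2)c1` is a close relative of compound 1. The change is hydrogen in place of methyl on an oxygen on an aromatic ring. Going by the values given here, no measured pair in this set shows what this change does, so there is no direct precedent.

The expectation for the step of a number 3 percentage points lower from compound 1 to compound 3 (within the scatter) is a small move downward, not beyond the scatter. Compound 3 is therefore estimated at 93%, with a range from 80% to 102%.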

Compound 3, a percentage reported as activity, at one concentration (the size of the read-out at that concentration, not a potency): 92%
For compound 3 the middle estimate is 1 percentage points above the measured one, within the range that was stated.
By their numbers in this assay, from the lowest: compounds 2, 3 and 1 (each within the scatter of the next).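

Going from methoxy to hydroxy on the outer ring gives a number 4 percentage points lower from compound 1 to compound 3 (within the scatter) in this assay, so replacing the methyl on this oxygen with hydrogen produces no difference that can be told from the scatter. Going by these compounds alone, this is the first measured pair here that differs in one place, and it gives a direct reading of this change, though at a single concentration only. No supporting data bear on why the two compounds read alike.

What the compounds shown leave open is whether the same change on compound 2, which also carries the methoxy group, would read the same way. On these data alone, it also remains open whether a longer chain on this oxygen, such as ethyl, or an amine in place of the hydroxy, would separate from compound 1 beyond the scatter.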